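Aryl hydrazone variation on a shared anilinoquinazoline core

The compounds below may be only part of what the source reports. "The series", "measured", "known", "first", "only" and "open" are said of these compounds alone.

Measured compounds:
Compound 1 `COc1cc(/C=N/NC(=O)Nc2cc3c(Nc4ccc(F)c(Cl)c4)ncnc3cc2O[C@H]2CCOC2)cc(OC)c1OC`: 26400 nM
Compound 2 `COc1cc2ncnc(Nc3ccc(F)c(Cl)c3)c2cc1NC(=O)N/N=C/c1cccc(Br)c1`: 28100 nM
Compound 3 `COc1cc2ncnc(Nc3ccc(F)c(Cl)c3)c2cc1NC(=O)N/N=C/c1cc(C(C)(C)C)c(O)c(C(C)(C)C)c1`: 37100 nM

The three measured compounds share a core and differ in the aryl group carried by the hydrazone. In a functional assay on A549 cells (Homo sapiens) for cytotoxicity, read by MTT assay, with a stated time of 72 h (a lower number here means a stronger inhibitor, a higher number a weaker inhibitor), compound 1 gives 26400 nM, compound 2 gives 28100 nM and compound 3 gives 37100 nM. Compound 2 holds the second highest of the three numbers; its nearest neighbour is compound 1 and its furthest is compound 3, and both of those gaps lie within the scatter, so the three compounds cannot be told apart on these values.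

Compound 4 `CCN(CC)c1ccc(/C=N/NC(=O)Nc2cc3c(Nc4ccc(F)c(Cl)c4)ncnc3cc2OC)c(O)c1` has not been measured. It differs from compound 2 at one place: 4-(diethylamino)-2-hydroxyphenyl in place of 3-bromophenyl on a carbon with a double bond to nitrogen. For the measured compounds named here, no pair of measured compounds that differ in only one place is available, so there is no measured step to lean on. Since the three measured aryl variants, a trimethoxyphenyl, a bromophenyl and a hindered phenol, all sit together within the scatter of one another, the expected step from compound 2 to compound 4 is a 1.0-fold lower number from compound 2 to compound 4 (0.02 log units; within the scatter), that is, none beyond the scatter. Compound 4 is therefore estimated to give 27000 nM in this assay, within a range from 10000 nM to 70000 nM.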

Compound 4, half-maximal inhibitory concentration: 27300 nM
For compound 4 the middle estimate is 1.0-fold (0.00 log units) below the measured one, within the range that was stated.
By their numbers in this assay, from the lowest: compounds 1, 4, 2 and 3 (each within the scatter of the next).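

For the compounds shown here, the exchange of 3-bromophenyl for 4-(diethylamino)-2-hydroxyphenyl on a carbon with a double bond to nitrogen is the first single-place step at this position, and in this assay it amounts to a 1.0-fold lower number from compound 2 to compound 4 (0.01 log units; within the scatter). The entering group is the larger of the two and carries a hydrogen-bond donor and hydrogen-bond acceptors that 3-bromophenyl lacks, yet these differences in structure come with no difference that can be told from the scatter, so at this position, for this pair, the assay does not separate the two aryl groups. Nothing among the available data bears on why the two compounds stand together.

The compounds shown leave open whether any group at this place would move the number beyond the scatter, since each group seen there so far is a substituted phenyl, and a carboxylic acid on that ring or a plain alkyl chain in place of it would test this. They also leave open whether a change elsewhere on the shared core, such as a different amine on the quinazoline-free side of the molecule, would matter more than the aryl group does.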